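Swapping the charged head group on a long ether chain

This account rests on a few compounds, and the source may have more. Where it says the series, first, only, none or still open, it means among the compounds named here.

Measured so far:
compound 1, `Cc1cc(-n2cc(C(=O)Nc3cc(F)cc(F)c3)c(=O)c3ccc(N(C)C)nc32)ccc1OCCCCCCC[n+]1ccccc1`, 55%
compound 2, `Cc1ccc(-n2cc(C(=O)Nc3cc(F)cc(F)c3)c(=O)c3ccc(N(C)C)nc32)cc1OCCCCCCC[n+]1ccccc1`, 22.2%
compound 3, `Cc1cc(-n2cc(C(=O)Nc3cc(F)cc(F)c3)c(=O)c3ccc(N(C)C)nc32)ccc1OCCCCCCC[N+]1(C)CCN(C)CC1`, 32%

Of the compounds shown here, three have been tested in an assay on LX2 cells for inhibition of COL1A1 promoter (Homo sapiens), read by a luciferase reporter, with a stated time of 24 h, tested at 50 uM; a lower number here means a weaker effect, a higher number a stronger effect of the compound at the concentration tested. Compound 1 and compound 2 are built from the same atoms joined differently, and the difference between the two cores is not broken down here. In this assay compound 1 gives 55%, while compound 2 gives 22.2%, a gap beyond the scatter.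

Compound 3 differs from compound 1 in one place: a group of 8 heavy atoms (6 carbon, 2 nitrogen; one six-membered non-aromatic ring with 2 hetero atoms) in place of a group of 6 heavy atoms (5 carbon, 1 nitrogen; one six-membered aromatic ring with 1 hetero atom), on a saturated chain carbon, seven bonds along the chain from an oxygen on an aromatic ring. That change gave a number 23 percentage points lower from compound 1 to compound 3 (beyond the scatter), so compound 3 stands at 32%, within the scatter of compound 2.

Compound 4, `Cc1ccc(-n2cc(C(=O)Nc3cc(F)cc(F)c3)c(=O)c3ccc(N(C)C)nc32)cc1OCCCCCCC[N+]1(C)CCN(C)CC1`, is not yet measured. It carries the same change on the core of compound 2: a group of 8 heavy atoms (6 carbon, 2 nitrogen; one six-membered non-aromatic ring with 2 hetero atoms) in place of a group of 6 heavy atoms (5 carbon, 1 nitrogen; one six-membered aromatic ring with 1 hetero atom), on a saturated chain carbon, seven bonds along the chain from an oxygen on an aromatic ring. The place of the change is the same in both pairs. Among the measured compounds shown here, the one measured example of this swap, from compound 1 to compound 3, was a modest drop, and compound 2 already starts low, so only a small further drop is expected, with the number unable to fall far; the step expected from compound 2 to compound 4 in this assay is a number 10.2 percentage points lower from compound 2 to compound 4 (beyond the scatter). On that basis compound 4 is estimated to give 12% in this assay, likely between -5% and 28%.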

Compound 4, a percentage reported as inhibition, at one concentration (the size of the read-out at that concentration, not a potency): 25%
Compound 4: the middle estimate sits 13 percentage points below what was measured; low and high end bracket the measured number.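

On the core of compound 2, putting the group with the six-membered non-aromatic ring in place of the group with the six-membered aromatic ring gave a number 2.8 percentage points higher from compound 2 to compound 4 (within the scatter) in this assay, so on this core the swap has no effect that can be told apart from scatter. The same change in the same place therefore did not carry over in size from one core to the other: the same change on two cores in this assay, a number 23 percentage points lower (beyond the scatter) from compound 1 to compound 3 and a number 2.8 percentage points higher (within the scatter) from compound 2 to compound 4, 25.8 percentage points apart, beyond the scatter of two such steps

Among the compounds shown here, this does not show why the two cores respond differently, and with only one pair on each core it gives no general rule for the series, only a warning that a step measured on one core cannot simply be added to the other; the read-out is also taken at a single concentration, so it speaks of the size of the effect there and not of potency.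

The compounds shown leave open how other head groups on the same chain, such as a trimethylammonium or an uncharged morpholine, would read on each of the two cores. They also leave open whether a shorter or a longer chain would make the two cores respond alike to the swap.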